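Working notes on passive permeability across a small series

A few compounds are considered here, and "the series" means these few. Any claim that something is new, unique, unknown or untested is made for them only; others in the source may bear on it.

compound 1 `COc1cccc(CNCCCNc2ccnc3cc(Oc4ccccc4)ccc23)c1O`: 317 10^-6 cm/s
compound 2 `COc1ccc(-c2ccc3c(NCCCNCc4cccc(OC)c4O)ccnc3c2)cc1`: 237 10^-6 cm/s
compound 3 `FC(F)(F)c1ccc(-c2ccc3c(NCCCNCc4ccco4)ccnc3c2)cc1`: 237 10^-6 cm/s

In an ADME assay for permeability, using PAMPA, with a stated time of 30 min, at pH 7.4 (on this read-out lower numbers stand for lower permeability and higher numbers for higher permeability), compound 3 gives 237 10^-6 cm/s, level with compound 2 at the digits shown, and the gap to compound 1 is within the scatter; the three measured numbers sit close together. Compound 4 `COc1cccc(Oc2ccc3c(NCCCNCc4ccco4)ccnc3c2)c1` is the next analogue; it carries 3-methoxyphenoxy in place of 4-(trifluoromethyl)phenyl on an aromatic carbon. Within the data shown here, the only measured step at this position, a 1.3-fold lower number from compound 1 to compound 2 (0.13 log units; within the scatter), exchanged an aryloxy group for an aryl group and stayed within the scatter, so a comparable exchange in the opposite sense is not expected to move the number beyond the scatter either. For compound 4 the expected value in this assay is 260 10^-6 cm/s, with a range of 150 10^-6 cm/s to 420 10^-6 cm/s. The expected step of a 1.1-fold higher number from compound 3 to compound 4 (0.04 log units; within the scatter) is therefore small.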

Compound 4, apparent permeability: 317 10^-6 cm/s
Compound 4: middle estimate off by 1.2-fold (0.09 log units), on the low side; low and high end bracket the measured number.
By their numbers in this assay, from the lowest: compounds 2, 3, 1 and 4 (each within the scatter of the next).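

In this assay the exchange at this aromatic carbon now reads in the opposite sense and with a different side chain, as a 1.3-fold higher number from compound 3 to compound 4 (0.13 log units; within the scatter), and like a 1.3-fold lower number from compound 1 to compound 2 (0.13 log units; within the scatter) it stays within the scatter. Across these two pairs, aryloxy and aryl groups at this carbon are not told apart by this read-out, even with 4-(trifluoromethyl)phenyl leaving and 3-methoxyphenoxy entering. No supporting data explain this result.

Open, from the compounds shown here alone, is whether an amine or a carboxylic acid at this carbon would give a step beyond the scatter. Also open, going by these compounds, is what a longer chain would do to the number.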